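Replacing trifluoromethoxy with (dimethylamino)methyl on the biaryl tail

A few compounds are considered here, and "the series" means these few. Any claim that something is new, unique, unknown or untested is made for them only; others in the source may bear on it.

Compound 3, `CC[C@H](C)[C@H](N)CN(C(=O)[C@@H]1C[C@H]1c1ccccc1)c1ccc(-c2ccc(OC(F)(F)F)cc2)cc1`, is measured in a functional assay for agonist activity at G protein-coupled receptor 88 (Homo sapiens), read by HTRF and cAMP accumulation (a lower number here means that less compound is needed, a higher number that more compound is needed for the effect), and gives 170 nM. Among the three measured compounds this is the second highest number: compound 2, `CCc1ccc(-c2ccc(N(C[C@@H](N)[C@@H](C)CC)C(=O)[C@@H]3C[C@H]3c3ccccc3)cc2)cc1`, gives 44 nM, while compound 1, `CC[C@H](C)[C@H](N)CN(C(=O)[C@@H]1C[C@H]1c1ccc(F)cc1F)c1ccc(-c2ccccc2)cc1`, gives 1300 nM. The new compound 4, `CC[C@H](C)[C@H](N)CN(C(=O)[C@@H]1C[C@H]1c1ccccc1)c1ccc(-c2ccc(CN(C)C)cc2)cc1`, differs from compound 3 in one place: (dimethylamino)methyl in place of trifluoromethoxy on an aromatic carbon.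

Within the data shown here, the only measured step that touches this position is a 3.9-fold higher number from compound 2 to compound 3 (0.59 log units; beyond the scatter), which shows that the substituent on the outer aromatic ring shifts the number by a modest amount. Among the measured compounds shown here, no measured compound carries (dimethylamino)methyl, so the direction of the present change cannot be read from the data. A step of similar size as between compound 2 and compound 3, in either direction, or none beyond the scatter, is plausible. Compound 4 is therefore expected to give 200 nM, with a range from 60 nM to 700 nM. This corresponds to an expected step of a 1.2-fold higher number from compound 3 to compound 4 (0.07 log units; within the scatter).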

Compound 4, half-maximal effective concentration: 460 nM
Compound 4: middle estimate off by 2.3-fold (0.36 log units), on the low side, within the range that was stated.
By their numbers in this assay, from the lowest: compound 2; then compound 3; then compound 4; then compound 1.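

In this assay the substituent on the outer ring now has a second measured change, a 2.7-fold higher number from compound 3 to compound 4 (0.43 log units; beyond the scatter), so (dimethylamino)methyl does not match trifluoromethoxy at this place. Set against ethyl, the same group gives a 10-fold higher number from compound 2 to compound 4 (1.02 log units; beyond the scatter), the largest step yet seen at this position, and the three groups now rank from the lowest number up as ethyl, trifluoromethoxy and (dimethylamino)methyl. Nothing at hand explains why the number moves with these groups.

On these data alone, it remains open whether a primary aminomethyl group or a carboxylic acid on this aromatic carbon would raise the number as (dimethylamino)methyl does. Also open, as far as these compounds go, is how a longer chain carrying the dimethylamino group, or a propyl group in place of ethyl, would compare with these compounds.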